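From 2,6-dichlorophenyl to 2-bromophenyl on the shared core

A few compounds are considered here, and "the series" means these few. Any claim that something is new, unique, unknown or untested is made for them only; others in the source may bear on it.

In a functional assay on B16-F10 cells (Mus musculus) for cytotoxicity (a higher number here means a weaker inhibitor, a lower number a stronger inhibitor), compound 2 `O=c1oc2ccccc2c2nc3c(ccc4cc[nH]c43)c(-c3c(Cl)cccc3Cl)c12` gives 70700 nM. That places it level with the other two measured compounds. Compound 1 `O=c1oc2ccccc2c2nc3c(ccc4cc[nH]c43)c(-c3ccc(C(F)(F)F)cc3)c12` gives 70700 nM, and compound 3 `O=c1cc(O)c2cc(F)ccc2o1`, which lacks the shared core, gives 70700 nM. Compound 4 `O=c1oc2ccccc2c2nc3c(ccc4cc[nH]c43)c(-c3ccccc3Br)c12` is not yet measured. It differs from compound 2 by one substituent: 2-bromophenyl in place of 2,6-dichlorophenyl on an aromatic carbon. The 2-bromophenyl group replaces 2,6-dichlorophenyl on an aromatic carbon, opposite the ring nitrogen. For the measured compounds named here, only one measured step bears on this carbon: no change at the digits printed from compound 1 to compound 2 (within the scatter). Going by the values given here, that single exchange of aryl groups gives no step beyond the scatter, though no compound carrying 2-bromophenyl has been measured. On that limited evidence, no step beyond the scatter, and no direction, is expected in this assay. The estimated step is no change at the digits printed from compound 2 to compound 4 (within the scatter). For compound 4 the estimated value is 70700 nM, with an expected range of 30000 nM to 120000 nM.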

Compound 4, half-maximal inhibitory concentration: 70700 nM
Compound 4: middle estimate and measured number agree at the digits printed; the range from low to high includes it.
By their numbers in this assay, from the lowest: compounds 1, 2, 3 and 4 (each within the scatter of the next).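

In this assay, the aryl exchange on the aromatic carbon opposite the ring nitrogen now has a second and third reading: 2-bromophenyl for 2,6-dichlorophenyl gives (no change at the digits printed from compound 2 to compound 4 (within the scatter)), and 2-bromophenyl for 4-(trifluoromethyl)phenyl gives (no change at the digits printed from compound 1 to compound 4 (within the scatter)). One bromine in place of two chlorines therefore leaves the number as it was, as does the exchange for trifluoromethyl, so these three aryl groups show no substituent trend at this carbon. No measurement on hand explains this sameness.

The compounds shown do not reveal whether any group at this carbon can move the number in either direction, as all three carry a substituted phenyl. An amine or a carboxylic acid on that phenyl ring, or a longer alkyl chain in its place, remains an open test.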